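Allyl-substituted diketopiperazine analogues: a 2-fluorophenyl variant

The compounds below may be only part of what the source reports. "The series", "measured", "known", "first", "only" and "open" are said of these compounds alone.

Measured so far, in a functional assay on MOLT-4 cells (Homo sapiens) for cytotoxicity, read by CCK-8 assay, with a stated time of 72 h; a lower number here means a stronger inhibitor, a higher number a weaker inhibitor:
Compound 1, `C=CCn1c(=O)/c(=C\c2cc(Br)ccc2F)[nH]c(=O)/c1=C\c1ccccc1OC`, gives 12900 nM.
Compound 2, `C=CCn1c(=O)/c(=C\c2cccc(Br)c2)[nH]c(=O)/c1=C\c1ccccc1OC`, gives 5000 nM.
Compound 3, `C=CCn1c(=O)/c(=C\c2cccc(C)c2)[nH]c(=O)/c1=C\c1ccccc1OC`, gives 16000 nM.

Compound 3 holds the highest of the three numbers in this assay. Its nearest neighbour is compound 1, at a 1.2-fold higher number from compound 1 to compound 3 (0.09 log units; within the scatter), which lies within the scatter; the gap to compound 2, at a 3.2-fold higher number from compound 2 to compound 3 (0.51 log units; beyond the scatter), is beyond the scatter.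

Compound 4, `C=CCn1c(=O)/c(=C\c2ccccc2F)[nH]c(=O)/c1=C\c1ccccc1OC`, differs from compound 3 in one place: 2-fluorophenyl in place of 3-methylphenyl on a double-bonded chain carbon bound to an aromatic carbon. Within the data shown here, no measured step makes exactly this change. Among the measured compounds shown here, two steps bear on it indirectly. The step of a 2.6-fold lower number from compound 1 to compound 2 (0.41 log units; beyond the scatter) shows what removing the fluoro did while a bromo stayed in place; the step of a 3.2-fold higher number from compound 2 to compound 3 (0.51 log units; beyond the scatter) shows that exchanging bromo for methyl raised the number. Compound 4 carries neither bromo nor methyl, only the fluoro that compound 1 also bears, and compound 1 sits close to compound 3.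

Compound 4 is therefore expected to stay near compound 3 in this assay, with an expected step of a 1.3-fold higher number from compound 3 to compound 4 (0.10 log units; within the scatter) that need not exceed the scatter. The estimate for compound 4 is 20000 nM, within a range from 7000 nM to 60000 nM.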

Compound 4, half-maximal inhibitory concentration: 20000 nM
Estimate against measurement, compound 4: no gap at the digits printed; the measured number falls inside the stated range.
By their numbers in this assay, from the lowest: compound 2; then compounds 1, 3 and 4 (each within the scatter of the next).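

In this assay, the step of a 1.3-fold higher number from compound 3 to compound 4 (0.10 log units; within the scatter) places 2-fluorophenyl and 3-methylphenyl level on the double-bonded chain carbon bound to an aromatic carbon, so these two groups cannot be told apart here. Among these compounds, the new compound also gives the first direct reading of the bromo with the fluoro in place: hydrogen in place of bromo gives a 1.6-fold higher number from compound 1 to compound 4 (0.19 log units; within the scatter) and stays level, while 2-fluorophenyl in place of 3-bromophenyl gives a 4.0-fold higher number from compound 2 to compound 4 (0.60 log units; beyond the scatter) and is a real change, which leaves compound 2 as the only one of the four set apart from the rest, with the lowest number. Nothing measured here bears on why these numbers fall as they do.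

The compounds shown leave open whether the low number of compound 2 is particular to the bromo or would also appear with a different group on this phenyl ring, such as a nitrile, an amine or a carboxylic acid. They also leave open how far any of these readings would hold if the allyl on the shared core gave way to a longer chain.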